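Replacing 4-bromophenyl with 2,3-dihydro-1H-inden-5-yl

This account rests on a few compounds, and the source may have more. Where it says the series, first, only, none or still open, it means among the compounds named here.

Within the data shown here, in a functional assay on the whole organism (strain Wistar) with Rattus norvegicus as the target, read by paw edema, at a dose of 30 mg/kg by the oral route (on this read-out lower numbers stand for an effect already at smaller amounts and higher numbers for an effect only at larger amounts of compound), compound 2 `CCC(=O)NS(=O)(=O)c1ccc(-n2nc(C(F)(F)F)cc2-c2ccc(Br)cc2)cc1COC(=O)CC` gives 37 mg/kg, the only compound here with a single number. Compound 1 `CCC(=O)NS(=O)(=O)c1ccc(-n2nc(C(F)(F)F)cc2-c2ccc(SC)cc2)cc1COC(=O)CC` gives 38 mg/kg; 40 mg/kg (2 entries) and compound 3 `CCC(=O)NS(=O)(=O)c1ccc(-n2nc(C(F)(F)F)cc2-c2ccc(OC)c(C)c2)cc1COC(=O)CC` gives 48 mg/kg; 34 mg/kg (2 entries), each from repeated entries, and all three lie within the usual scatter of one another. Compound 4 `CCC(=O)NS(=O)(=O)c1ccc(-n2nc(C(F)(F)F)cc2-c2ccc3c(c2)CCC3)cc1COC(=O)CC` has 2,3-dihydro-1H-inden-5-yl in place of the 4-bromophenyl of compound 2, on an aromatic carbon (2,3-dihydro-1H-inden-5-yl in place of 4-bromophenyl on an aromatic carbon). Compound 4 is expected to stay level with compound 2 in this assay because compound 1 at 38 mg/kg; 40 mg/kg (2 entries) and compound 3 at 48 mg/kg; 34 mg/kg (2 entries) carry other groups in that place yet stay level with compound 2. The expected change is a 1.1-fold higher number from compound 2 to compound 4 (0.03 log units; within the scatter). Compound 4 is estimated at 40 mg/kg, with an expected range of 22 mg/kg to 72 mg/kg.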

Compound 4, dose for half-maximal effect: 41 mg/kg
Beside the measured number, compound 4's estimate is 1.0-fold (0.01 log units) below it, and the stated range covers the measured number.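

In this assay, among these compounds, replacing 4-bromophenyl with 2,3-dihydro-1H-inden-5-yl gives a 1.1-fold higher number from compound 2 to compound 4 (0.04 log units; within the scatter), so this place also tolerates a second, five-membered non-aromatic ring, which the earlier compounds did not carry. The bromine can go without the number leaving the scatter. The step is no larger than the spread among repeats of a single compound: the several entries of compound 3 in this assay, 48 mg/kg; 34 mg/kg (2 entries)

From the compounds shown here alone, it remains open whether an amine or a carboxylic acid in this place would stay level. No group shown here yet moves the number beyond the scatter.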